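Methyl for Methoxy: One Small Change on Compound 1

The compounds below may be only part of what the source reports. "The series", "measured", "known", "first", "only" and "open" are said of these compounds alone.

Compound 1 `COc1ccc(C(=O)CCC(=O)NCCCO)cc1` was tested in a functional assay on the whole organism (Central nervous system) for activation, with Mus musculus as the target (a lower number here means that less compound is needed, a higher number that more compound is needed for the effect), where compound 1 gives 150 mg/kg. For the measured compounds named here, that is the only plain number in hand; the other entry is a limit. Compound 2 `O=C1CCCC2(c3ccccc3)OCCCN12` gives only a limit of the assay, < 50 mg/kg (the limit of < 50 mg/kg in this assay, at which 1 of the 2 values shown sits).

Compound 3 `Cc1ccc(C(=O)CCC(=O)NCCCO)cc1` has not yet been measured there. It differs from compound 1 in a single place (methyl in place of methoxy on an aromatic carbon). Going by the values given here, no measured pair shows this kind of swap, so nothing beyond the usual scatter is expected in this assay. The step of no change at the digits printed from compound 1 to compound 3 (within the scatter) is expected to be small. Compound 3 is therefore estimated at 150 mg/kg, within 70 mg/kg to 320 mg/kg.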

Compound 3, dose for half-maximal effect: 300 mg/kg
The estimate for compound 3 lay 2.0-fold (0.30 log units) below the measured number, within the range that was stated.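

In this assay, methyl in place of methoxy on this aromatic carbon gives a 2.0-fold higher number from compound 1 to compound 3 (0.30 log units; within the scatter). For the compounds shown here, this is the first measured pair at this position, and it shows that removing the oxygen of the methoxy, along with its hydrogen-bond acceptor, does not shift the number beyond the usual variation between repeats. Nothing measured here accounts for the size of this step. The compounds shown leave open what an amine, a carboxylic acid or a longer chain on this aromatic carbon would do.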